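Trading Methyl for Trifluoromethyl in a Cytotoxicity Series

A few compounds are considered here, and "the series" means these few. Any claim that something is new, unique, unknown or untested is made for them only; others in the source may bear on it.

Two compounds sharing one core have been run in a functional assay on L1210 cells (Mus musculus) for cytotoxicity, read by cell counting, with a stated time of 2 days; on this read-out higher numbers stand for weaker inhibition and lower numbers for stronger inhibition. Compound 1 `Nc1ccc(/C=C2\SC(=O)N(Cc3ccc(Cl)cc3)C2=O)cc1` gives 37000 nM in this assay. Compound 2 `C=C(Br)C(=O)Nc1ccc(/C=C2\SC(=O)N(Cc3ccc(C)cc3)C2=O)cc1` gives 3400 nM in this assay. Within the data shown here, of the two numbers, compound 2 holds the lower one; its only neighbour is compound 1, whose number stands higher by a margin beyond the usual scatter. Among the measured compounds shown here, the two measured compounds differ in more than one place, so no single-point step between them can be drawn, and no measured pair yet shows what a change on the aromatic ring of the benzylic substituent does.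

Compound 3 `C=C(Br)C(=O)Nc1ccc(/C=C2\SC(=O)N(Cc3ccc(C(F)(F)F)cc3)C2=O)cc1` has not been measured. It differs from compound 2 in one place: trifluoromethyl in place of methyl on an aromatic carbon. For the measured compounds named here, no measured step speaks to this exchange. The expectation rests on compound 2 alone. The step from compound 2 to compound 3 is expected to be small, most likely within the scatter, with a slight lean toward a lower number, a 1.4-fold lower number from compound 2 to compound 3 (0.13 log units; within the scatter). Compound 3 is therefore estimated at 2500 nM, within a range from 800 nM to 8000 nM.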

Compound 3, half-maximal inhibitory concentration: 12000 nM
For compound 3 the middle estimate is 4.8-fold (0.68 log units) below the measured one, and the stated range ends below it.
By their numbers in this assay, from the lowest: compound 2; then compound 3; then compound 1.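

In this assay, among these compounds, the exchange of methyl for trifluoromethyl on an aromatic carbon, para to a large group, gives a 3.5-fold higher number from compound 2 to compound 3 (0.55 log units; beyond the scatter), and this is the first reading of a single change on this ring. It shows that this position is not indifferent to what it carries: with the rest of compound 2 held constant, the change from 4-methylphenyl to 4-(trifluoromethyl)phenyl moves the number beyond the scatter, toward weaker inhibition, although the size of the step is modest. No measurement shown here offers an explanation for this step.

One step cannot tell whether other groups at this carbon would follow the direction seen with trifluoromethyl, or how a methoxy group, an amine or a plain hydrogen would compare with methyl on the same core. Chlorine appears on this ring only in compound 1, which also differs from compound 2 at the amino end of the molecule, so the effect of a chlorine at this place, with the bromine-bearing amide kept, remains open.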